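A few compounds are considered here, and "the series" means these few. Any claim that something is new, unique, unknown or untested is made for them only; others in the source may bear on it.

Of the compounds shown here, three of one shared core have been measured in a functional assay on T47D cells (Homo sapiens) for cytotoxicity, with a stated time of 72 h, tested at 50 ug/mL; a lower number here means a weaker effect, a higher number a stronger effect of the compound at the concentration tested. Compound 1, `O=c1[nH]nc2n(c1=O)CCN2c1ccccc1`, carries an unsubstituted aromatic ring, and in this assay compound 1 gives 0%. Compound 2, `Cc1ccc(N2CCn3c2n[nH]c(=O)c3=O)cc1`, bears a methyl on an aromatic carbon, and in this assay compound 2 gives 22%. Compound 3, `COc1ccc(N2CCN/C2=N\N)cc1`, is built on a different core, and in this assay compound 3 gives 23%. Within the data shown here, the step of a number 22 percentage points higher from compound 1 to compound 2 (beyond the scatter) is the only measured step between two compounds that differ in one place. Compound 2 stands in the middle of the three numbers: compound 3 lies within the scatter of it, while compound 1 sits clearly lower.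

Compound 4, `O=c1[nH]nc2n(c1=O)CCN2c1ccc(Cl)cc1`, is the next variation: chloro in place of methyl on an aromatic carbon. Among the measured compounds shown here, no measured step swaps one group on this aromatic carbon for another; the only step touching this position is the one from compound 1 to compound 2, a modest gain. With nothing measured for a swap of this kind, the expectation rests on the value of compound 2, 22%, and is a change of a number 3 percentage points higher from compound 2 to compound 4 (within the scatter), that is no step beyond the scatter. Compound 4 is therefore estimated at 25% in this assay, with a likely range from 5% to 45%.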

Compound 4, a percentage reported as inhibition, at one concentration (the size of the read-out at that concentration, not a potency): 1%
Beside the measured number, compound 4's estimate is 24 percentage points above it; measured number below the stated range.
By their numbers in this assay, from the lowest: compounds 1 and 4 (each within the scatter of the next); then compounds 2 and 3 (each within the scatter of the next).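

In this assay, chloro in place of methyl gives a number 21 percentage points lower from compound 2 to compound 4 (beyond the scatter), while chloro in place of hydrogen gives a number 1 percentage points higher from compound 1 to compound 4 (within the scatter), so on this aromatic carbon, para to a large group, chloro leaves the read-out where the unsubstituted ring had it. Until now, the only change at this position was the gain seen with methyl, which could have meant that any small group placed here would raise the number; among these three compounds, that gain belongs to methyl alone, even though methyl and chloro are both counted as one heavy atom and neither has a hydrogen-bond donor or acceptor. Nothing in the available data explains why these two groups part ways.

On these data alone, whether a longer chain such as ethyl, an amine or a carboxylic acid at this position would behave like methyl or like chloro remains open. Also open, as far as these compounds go, is whether the methyl result would hold with methyl elsewhere on the aromatic ring, since each number here is the size of the effect at a single concentration, drawn from very few compounds.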